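A few compounds are considered here, and "the series" means these few. Any claim that something is new, unique, unknown or untested is made for them only; others in the source may bear on it.

Compound 1 `COc1ccc(-n2nc(C(=O)Nc3ccccc3OC)nc2-c2cc(OC)c(OC)c(OC)c2)cc1` stands lowest of the two measured compounds in a functional assay on the whole organism for inhibition, with Rattus norvegicus as the target, read by paw edema, with stated times of 30 min and 5 h, at a dose of 0.28 mmol/kg by the oral route; on this read-out lower numbers stand for less inhibition and higher numbers for more inhibition at the one dose given (going by the name of the read-out): compound 1 gives 10%, while compound 2 `COc1ccc(-n2nc(C(=O)Nc3ccc(C(F)(F)F)cc3)nc2-c2cc(OC)c(OC)c(OC)c2)cc1` gives 50%. Among the compounds with values here, the one measured step, a number 40 percentage points higher from compound 1 to compound 2 (beyond the scatter), shows that the group on the amide-type nitrogen can shift the read-out by a large amount. Compound 3 `COc1ccc(-n2nc(C(=O)Nc3ccc(O)cc3)nc2-c2cc(OC)c(OC)c(OC)c2)cc1` differs from compound 1 by 4-hydroxyphenyl in place of 2-methoxyphenyl on an amide-type nitrogen. This change takes away the same 2-methoxyphenyl as the measured step but brings in a different group, so that step bears on it only in part. Within the data shown here, since the measured step ran upward, a rise of moderate size is expected for compound 3, with wide uncertainty, as no measured compound carries 4-hydroxyphenyl. Compound 3 is expected to give 30%, between 5% and 55%. The expected step is a number 20 percentage points higher from compound 1 to compound 3 (beyond the scatter), estimated smaller than the measured step.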

Compound 3, a percentage reported as inhibition, in the whole organism at one dose (the size of the read-out at that dose, not a potency): 27%
Compound 3: the middle estimate sits 3 percentage points above what was measured, within the range that was stated.
By their numbers in this assay, from the lowest: compound 1; then compound 3; then compound 2.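

In this assay, a second group in place of 2-methoxyphenyl on the amide-type nitrogen also raises the number, with 4-hydroxyphenyl giving a number 17 percentage points higher from compound 1 to compound 3 (beyond the scatter). The replacement group matters as well as the loss of 2-methoxyphenyl: hydroxy in place of trifluoromethyl on an aromatic carbon gives a number 23 percentage points lower from compound 2 to compound 3 (beyond the scatter), which places 4-hydroxyphenyl in the middle of the three groups. Nothing available explains this order.

The step between 2-methoxyphenyl and 4-hydroxyphenyl changes both the oxygen-bearing group and its place on the ring, so the compounds shown cannot separate these two changes. A 4-methoxyphenyl group on the same nitrogen would bear on that question, while a 4-aminophenyl or 4-carboxyphenyl group would show how other groups compare with hydroxy and trifluoromethyl.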